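Fluorine Placement on the Phenyl Group at the Ring Nitrogen

The source may report more compounds than this note shows. Statements on the series, on what has been measured and on what is new or still open speak of the compounds shown alone.

Three measured compounds share one core and differ only in the phenyl group attached to an amine nitrogen in a ring. Compound 1 `O=C1Nc2ccc(Cl)cc2/C1=N/NC(=S)N1CCN(c2ccc(Cl)cc2)CC1` gives 5390 nM in a functional assay on HCT-116 cells (Homo sapiens) for inhibition, read by MTT assay, with a stated time of 72 h; a higher number here means a weaker inhibitor, a lower number a stronger inhibitor. Compound 2 `O=C1Nc2ccc(Cl)cc2/C1=N/NC(=S)N1CCN(c2ccccc2Cl)CC1` gives 4910 nM in this assay, and compound 3 `O=C1Nc2ccc(Cl)cc2/C1=N/NC(=S)N1CCN(c2ccc(F)cc2)CC1` gives 6350 nM in this assay. Compound 3 carries the highest of the three numbers, yet the differences to it are small: a 1.2-fold higher number from compound 1 to compound 3 (0.07 log units; within the scatter) and a 1.3-fold higher number from compound 2 to compound 3 (0.11 log units; within the scatter), both within the scatter.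

Compound 4 `O=C1Nc2ccc(Cl)cc2/C1=N/NC(=S)N1CCN(c2ccccc2F)CC1` has the same atoms as compound 3 joined differently: 2-fluorophenyl in place of 4-fluorophenyl on an amine nitrogen in a ring. For the measured compounds named here, the one measured step that bears on this change is a 1.1-fold lower number from compound 1 to compound 2 (0.04 log units; within the scatter), where the chloro substituent was moved in the same way and nothing beyond the scatter resulted. On that basis no step beyond the scatter is expected in this assay for compound 4. Compound 4 is therefore estimated to give 6000 nM, with a range from 3000 nM to 12000 nM. The expected step is a 1.1-fold lower number from compound 3 to compound 4 (0.02 log units; within the scatter).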

Compound 4, half-maximal inhibitory concentration: 8290 nM
Beside the measured number, compound 4's estimate is 1.4-fold (0.14 log units) below it, and the stated range covers the measured number.
By their numbers in this assay, from the lowest: compounds 2, 1, 3 and 4 (each within the scatter of the next).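

In this assay, 2-fluorophenyl in place of 4-fluorophenyl on this ring nitrogen gives a 1.3-fold higher number from compound 3 to compound 4 (0.12 log units; within the scatter), so moving the fluoro substituent, like moving the chloro substituent earlier, produces no step beyond the scatter. Changing the halogen and its place together gives a 1.5-fold higher number from compound 1 to compound 4 (0.19 log units; within the scatter), and exchanging chloro for fluoro at the same place gives a 1.7-fold higher number from compound 2 to compound 4 (0.23 log units; within the scatter), so these steps also remain within the scatter. The exchange of chloro for fluoro reads alike in both places on the phenyl group: the same change on two cores in this assay, a 1.2-fold higher number (0.07 log units; within the scatter) from compound 1 to compound 3 and a 1.7-fold higher number (0.23 log units; within the scatter) from compound 2 to compound 4, 1.4-fold (0.16 log units) apart, within the scatter of two such steps.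

The compounds shown carry only chloro or fluoro on this phenyl group, so they leave open whether a methoxy group, an amine or a carboxylic acid there would give a step beyond the scatter in this assay. They also leave open how a benzyl group in place of the phenyl group would read.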